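This account rests on a few compounds, and the source may have more. Where it says the series, first, only, none or still open, it means among the compounds named here.

- compound 1 `CCOC(=O)c1csc2nc(-c3cccc(NC(=O)CC)c3)cn12` gives > 20000 nM 
- compound 2 `CCOC(=O)c1csc2nc(-c3ccc(NS(=O)(=O)c4ccc(C)cc4)cc3)cn12` gives > 20000 nM 

Both compounds were tested in a functional assay on MV4-11 cells (Homo sapiens) for cytotoxicity, read by MTT assay, with a stated time of 72 h (on this read-out lower numbers stand for stronger inhibition and higher numbers for weaker inhibition), and neither gave a true number. In this assay compound 1 gives > 20000 nM and this is a limit of the assay, not a number. Compound 2 gives > 20000 nM and this too is only a limit. So compound 1 stands at the ceiling of the measurement, with the limit of > 20000 nM in this assay, at which 2 of the 2 values shown sit, as the whole of the evidence so far.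

The next compound, compound 3 `CCOC(=O)c1csc2nc(-c3cccc(NC(=O)CCl)c3)cn12` keeps the core of compound 1 and changes one small part of the side chain. It has chloro in place of methyl on a saturated chain carbon bound to a carbonyl carbon, so that propanoylamino becomes ((chloromethyl)carbonyl)amino chloro in place of methyl on a saturated chain carbon bound to a carbonyl carbon as the counted difference. Within the data shown here, no measured pair shows what such a swap does here, so any forecast is rough. A move toward stronger inhibition is expected, of modest and uncertain size, and another limit remains quite possible. The estimated step of an at least 2.5-fold lower number from compound 1 to compound 3 (0.39 log units; beyond the scatter) is measured from a limit and is therefore loose. For compound 3 the expected value is 8000 nM with an estimated range from 1500 nM to 30000 nM in this cell test.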

Compound 3, half-maximal inhibitory concentration: 17700 nM
Compound 3: middle estimate off by 2.2-fold (0.34 log units), on the low side; measured number inside the range.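

In this assay compound 3 gives 17700 nM, the first true number among the compounds shown, so the end of this side chain now has a reading that can serve as a point of comparison. Placing chloro in place of methyl on a saturated chain carbon bound to a carbonyl carbon gives an at least 1.1-fold lower number from compound 1 to compound 3 (0.05 log units; that floor lies within the scatter); this step starts from a limit, so its true size is unknown, and its floor lies within the usual scatter, so it does not establish a real gain in strength. The series therefore still rests more on limits than on numbers: the limit of > 20000 nM in this assay, at which 2 of the 3 values shown sit.

From the compounds shown here alone, it remains open whether chloro itself matters at this carbon, or whether another group there, such as bromo, hydroxy or a dimethylamino group, would give a clearly lower number. Also open, going by these compounds, is how a longer chain in place of the chloromethyl end, or a carboxylic acid in place of the ethyl ester on the shared core, would read in this assay.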